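Hydroxy for nitro on the aryl of compound 3

The source may hold more compounds than are shown below. What is called first, only, known or untested is meant among the compounds shown, and "the series" means these compounds.

Measured so far:
compound 1 `O=C(CSc1nnc(-c2ccncc2)o1)N/N=C/c1ccc(O)cc1` — 11700 nM
compound 2 `COc1cccc(/C=N/NC(=O)CSc2nnc(-c3ccncc3)o2)c1` — 13800 nM
compound 3 `O=C(CSc1nnc(-c2ccncc2)o1)N/N=C/c1ccccc1[N+](=O)[O-]` — 35600 nM

In a functional assay on MCF7 cells (Homo sapiens) for cytotoxicity, read by MTT assay, with a stated time of 48 h (on this read-out lower numbers stand for stronger inhibition and higher numbers for weaker inhibition), compound 3 gives the highest number of the three: a 3.0-fold higher number from compound 1 to compound 3 (0.48 log units; beyond the scatter) and a 2.6-fold higher number from compound 2 to compound 3 (0.41 log units; beyond the scatter), both beyond the scatter, while a 1.2-fold higher number from compound 1 to compound 2 (0.07 log units; within the scatter) is within it. Compound 4 `O=C(CSc1nnc(-c2ccncc2)o1)N/N=C/c1ccccc1O` differs from compound 3 by hydroxy in place of nitro on an aromatic carbon, the hydroxy ortho to a large group. Going by the values given here, no measured pair swaps nitro for hydroxy on the same carbon; the only bearing steps are the modest ones from compound 1 and compound 2 to compound 3, which place the nitro analogue at the weak end. On that basis a lower number than compound 3 is expected for compound 4, roughly a 2.0-fold lower number from compound 3 to compound 4 (0.30 log units; within the scatter), with the 4-hydroxy compound 1 as the reference point. Compound 4 is therefore estimated at 18000 nM in this assay, within 9000 nM to 36000 nM.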

Compound 4, half-maximal inhibitory concentration: 4750 nM
Beside the measured number, compound 4's estimate is 3.8-fold (0.58 log units) above it, outside the stated range (below it).
By their numbers in this assay, from the lowest: compound 4; then compounds 1 and 2 (each within the scatter of the next); then compound 3.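

In this assay, this aromatic carbon, ortho to a large group, is sensitive to the substituent, and hydroxy in place of nitro gives a 7.5-fold lower number from compound 3 to compound 4 (0.87 log units; beyond the scatter). Where the hydroxy sits also matters, as 2-hydroxyphenyl in place of 4-hydroxyphenyl gives a 2.5-fold lower number from compound 1 to compound 4 (0.39 log units; beyond the scatter), and 2-hydroxyphenyl in place of 3-methoxyphenyl gives a 2.9-fold lower number from compound 2 to compound 4 (0.46 log units; beyond the scatter). No evidence on record accounts for this order. Open, as far as these compounds go, is whether an amine or a carboxylic acid on that aromatic carbon would match compound 4, and whether the order holds in other cell lines.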